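Isopropyl in place of methyl: compound 2 to compound 3

The source may hold more compounds than are shown below. What is called first, only, known or untested is meant among the compounds shown, and "the series" means these compounds.

Compound 2 `C[C@H](NC(=O)c1ccc(Cl)cc1O)C(=O)Nc1ccc(Cl)cc1` has been tested in a functional assay on MCF7 cells (Homo sapiens) for cytotoxicity, with a stated time of 72 h; on this read-out lower numbers stand for stronger inhibition and higher numbers for weaker inhibition. In this assay compound 2 gives > 10000 nM, which is a limit of the assay and not a number. Compound 1 `CC(C)[C@H](NC(=O)c1cc(Cl)ccc1O)C(=O)Nc1ccc(Cl)cc1` carries the isopropyl on the saturated chain carbon but differs from compound 2 in the substitution pattern of one ring as well. In this assay compound 1 gives > 10000 nM, again a limit. Compound 2 therefore stands at the limit, and nothing is known of where it would fall below it; the limit of > 10000 nM in this assay, at which 2 of the 2 values shown sit, records that both values obtained so far sit there.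

Compound 3 `CC(C)[C@H](NC(=O)c1ccc(Cl)cc1O)C(=O)Nc1ccc(Cl)cc1` is not yet measured. It differs from compound 2 by isopropyl in place of methyl on a saturated chain carbon bound to an amide-type nitrogen and a carbonyl carbon. Among the compounds with values here, no measured pair isolates this change. Since compound 1, which already carries the isopropyl, reaches only the limit > 10000 nM, the step expected from compound 2 to compound 3 is a step that the limit leaves unreadable from compound 2 to compound 3, none beyond the scatter, most probably another limit. Compound 3 is estimated at 15000 nM, within 5000 nM to 50000 nM.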

Compound 3, half-maximal inhibitory concentration: > 10000 nM
Compound 3: only a limit was reported; the forecaster's own chance of this, stated with the estimate: 80%; the middle value does not contradict the limit.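

In this assay compound 3 gives > 10000 nM, a limit of the assay and not a number. Within the data shown here, compound 1 and compound 2 also stand at limits, so no step to compound 3 can be read. The compounds shown leave open whether either change alters the read-out, or how any of the three would rank: the limit of > 10000 nM in this assay, at which 3 of the 3 values shown sit.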